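This account rests on a few compounds, and the source may have more. Where it says the series, first, only, none or still open, it means among the compounds named here.

Measured so far:
Compound 1 `Cc1cc(NC(=O)Nc2ccccc2OC(F)(F)F)c2ccccc2n1`: > 25000 nM (a limit)
Compound 2 `Cc1cc(NC(=O)Nc2ccc(N)cc2)c2ccccc2n1`: > 25000 nM (a limit)

In an ADME assay on HepG2 cells (Homo sapiens) for cytotoxicity, with a stated time of 72 h (on this read-out higher numbers stand for an effect only at larger amounts of compound and lower numbers for an effect already at smaller amounts), compound 2 gives > 25000 nM, which is a limit of the assay and not a number. Among the compounds with values here, the series so far offers only (the limit of > 25000 nM in this assay, at which 2 of the 2 values shown sit), and no step between measured compounds is available.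

The next compound is compound 3 `Cc1cc(NC(=O)Nc2ccccc2F)c2ccccc2n1`. It follows from compound 2 by 2-fluorophenyl in place of 4-aminophenyl on an amide-type nitrogen, with 2-fluorophenyl in place of 4-aminophenyl on an amide-type nitrogen. The expectation leans on compound 1, which also stays at its limit of > 25000 nM. The expected change a number no higher from compound 2 to compound 3 (the limit leaves the size open) is none beyond the scatter, in either direction, and another report as a limit is likely. For compound 3 the estimated value is 25000 nM, with an expected range from 10000 nM to 50000 nM.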

Compound 3, half-maximal effective concentration: > 25000 nM
Compound 3: no number, only a limit (the forecaster's own chance of this, stated with the estimate: 85%); the middle value lies on the limit itself.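

No step can be read from compound 1 or compound 2 to compound 3, since in this assay all three are reported only as limits: the limit of > 25000 nM in this assay, at which 3 of the 3 values shown sit. The compounds shown leave open at what concentration, if any, each of them would have an effect on these cells.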